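Chain-end variation in a homocysteine-like thioether acid series

The source may hold more compounds than are shown below. What is called first, only, known or untested is meant among the compounds shown, and "the series" means these compounds.

Measured so far: compound 1 `NC(=O)C(N)CCSCCCCC(=O)O` gives 17% in an assay on isolated protein for inhibition of betaine--homocysteine S-methyltransferase 1 (Homo sapiens), with a stated time of 30 min, tested at 20 uM; on this read-out lower numbers stand for less inhibition and higher numbers for more inhibition at the one concentration tested (going by the name of the read-out); compound 2 `N#CC(N)CCSCCCCC(=O)O` gives 9% in this assay.

Compound 2 holds the lowest of the two numbers seen, with compound 1 nearest, the step being a number 8 percentage points lower from compound 1 to compound 2 (within the scatter), so the two compounds are not separated on this read-out.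

The next compound, compound 3 `NC(CCSCCCCC(=O)O)c1nnn[nH]1`, differs from compound 2 by 1H-tetrazol-5-yl in place of cyano on a saturated chain carbon bound to an amine nitrogen and a saturated chain carbon.

Among the measured compounds shown here, only one measured step exists, that from compound 1 to compound 2, and it exchanged carbamoyl for cyano at the same place without moving the read-out beyond the scatter. For the measured compounds named here, no measured step covers the entry of a 1H-tetrazol-5-yl group, so the expectation rests on the low level of both measured compounds, with room for an upward move that the data neither support nor rule out. The expected step is a number 16 percentage points higher from compound 2 to compound 3 (beyond the scatter).

Compound 3 is estimated at 25% in this assay, with a range from 5% to 55%.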

Compound 3, a percentage reported as inhibition, at one concentration (the size of the read-out at that concentration, not a potency): 0%
Compound 3: middle estimate off by 25 percentage points, on the high side; the whole stated range lies above it.
By their numbers in this assay, from the lowest: compounds 3, 2 and 1 (each within the scatter of the next, the first and the last beyond it).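

At the saturated chain carbon bound to an amine nitrogen and a saturated chain carbon, 1H-tetrazol-5-yl and cyano are not separated in this assay, with a number 9 percentage points lower from compound 2 to compound 3 (within the scatter). Against carbamoyl, 1H-tetrazol-5-yl gives the only step in the series beyond the scatter, though a modest one, with a number 17 percentage points lower from compound 1 to compound 3 (beyond the scatter), so carbamoyl is separated from 1H-tetrazol-5-yl but not from cyano. No measured evidence bears on what lies behind this result.

A carboxylic acid or a methyl ester at this place remains an open case, so the series does not yet show how far the read-out can move through this position. Also open, from the compounds shown here alone, is how carbamoyl, cyano and 1H-tetrazol-5-yl compare on a longer chain than that of the shared core, or with an acetamide in place of the amine.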